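The source may hold more compounds than are shown below. What is called first, only, known or untested is meant among the compounds shown, and "the series" means these compounds.

Three ureas share one core and differ only in the group on the outer aromatic ring. Compound 1 `Cc1ccc(NC(=O)Nc2cc(C)nc3ccccc23)cc1` carries a methyl group there. In an ADME assay on BJ cells (Homo sapiens) for cytotoxicity, with a stated time of 72 h (a lower number here means that less compound is needed, a higher number that more compound is needed for the effect), compound 1 gives only a limit of the assay, > 25000 nM. Compound 2 `Cc1cc(NC(=O)Nc2ccc(F)cc2)c2ccccc2n1` carries fluorine instead. In this assay compound 2 also gives only a limit, > 25000 nM. For the measured compounds named here, the one measured step, a step that the two limits leave unreadable from compound 1 to compound 2, therefore has no readable size. Compound 3 `COc1cccc(NC(=O)Nc2cc(C)nc3ccccc23)c1` carries a methoxy group. In this assay, going by the values given here, compound 3 gives 27000 nM, the only true number among the three values. It sits right beside (the limit of > 25000 nM in this assay, at which 2 of the 3 values shown sit), so compound 3 stands at the weak end of what this assay can report.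

Compound 4 `Cc1cc(NC(=O)Nc2cccc(F)c2)c2ccccc2n1` has not been measured. It differs from compound 3 in a single place, (fluoro in place of methoxy on an aromatic carbon). Among the compounds with values here, the only measured step also swaps a small group for fluorine on that ring, but both of its ends are limits, so it shows nothing about size or direction. With compound 3 at 27000 nM and no readable precedent, compound 4 is expected to stay close to that value. The step from compound 3 to compound 4 is estimated at a 1.1-fold higher number from compound 3 to compound 4 (0.05 log units; within the scatter). Compound 4 is expected to give 30000 nM, within 13000 nM to 70000 nM, in this assay.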

Compound 4, half-maximal effective concentration: > 25000 nM
Compound 4 ended at the assay's limit (the forecaster's own chance of this, stated with the estimate: 60%); the middle value is on the limit's open side.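

In this assay compound 4 gives > 25000 nM, which is a limit of the assay. Its steps from compound 1, compound 2 and compound 3 therefore cannot be read. The compounds shown leave open whether, and how far, changing the group on the outer aromatic ring moves the number in this assay.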